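Amide variants on the shared core: toward compound 4

The source may report more compounds than this note shows. Statements on the series, on what has been measured and on what is new or still open speak of the compounds shown alone.

Measured so far:
compound 1, `CCOC(=O)c1c(O)c2cccnc2n(-c2ccccc2)c1=O`: 23.5%
compound 2, `Cc1ccc(NC(=O)c2c(O)c3cccnc3n(-c3ccccc3)c2=O)cc1`: -3.5%
compound 3, `Cc1cccc(NC(=O)c2c(O)c3cccnc3n(-c3ccccc3)c2=O)c1`: 14.2%

In a functional assay on the whole organism for inhibition, with Rattus norvegicus as the target, read by paw edema, at a dose of 100 mg/kg by the oral route (on this read-out higher numbers stand for more inhibition at the one dose given (going by the name of the read-out) and lower numbers for less inhibition), compound 2 stands lowest of the three numbers. Its nearest neighbour is compound 3, with the step of a number 17.7 percentage points higher from compound 2 to compound 3 (beyond the scatter); the furthest is compound 1, with the step of a number 27 percentage points lower from compound 1 to compound 2 (beyond the scatter). The unmeasured compound 4, `O=C(Nc1cnccn1)c1c(O)c2cccnc2n(-c2ccccc2)c1=O`, differs from compound 2 by pyrazin-2-yl in place of 4-methylphenyl on an amide-type nitrogen. Among the compounds with values here, the one step that bears on a swap at the amide-type nitrogen is a number 17.7 percentage points higher from compound 2 to compound 3 (beyond the scatter), a modest rise; the steps of a number 27 percentage points lower from compound 1 to compound 2 (beyond the scatter) and a number 9.3 percentage points lower from compound 1 to compound 3 (within the scatter) concern the replacement of ethoxy and say little here. Within the data shown here, no measured step exchanges a carbon-only ring for one with hetero atoms, so a small rise at most is expected: a number 11.5 percentage points higher from compound 2 to compound 4 (beyond the scatter). Compound 4 is therefore estimated at 8%, within -10% to 26%.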

Compound 4, a percentage reported as inhibition, in the whole organism at one dose (the size of the read-out at that dose, not a potency): 29.6%
The estimate for compound 4 lay 21.6 percentage points below the measured number; the measured number lies above the stated range.
By their numbers in this assay, from the lowest: compound 2; then compounds 3, 1 and 4 (each within the scatter of the next, the first and the last beyond it).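

In this assay, pyrazin-2-yl on the amide-type nitrogen brings the first ring with hetero atoms to this position, and it separates clearly from both methylphenyl amides (a number 33.1 percentage points higher from compound 2 to compound 4 (beyond the scatter); a number 15.4 percentage points higher from compound 3 to compound 4 (beyond the scatter)). Replacing ethoxy on the carbonyl carbon with (pyrazin-2-yl)amino leaves the ester and this amide unresolved (a number 6.1 percentage points higher from compound 1 to compound 4 (within the scatter)), so an amide here need not fall short of the ester. No available evidence bears on the origin of these steps.

On these data alone, whether the ring nitrogens or the loss of methyl drives the difference remains open. A plain phenyl or a pyridin-2-yl on the same nitrogen would help to separate them.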